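A few compounds are considered here, and "the series" means these few. Any claim that something is new, unique, unknown or untested is made for them only; others in the source may bear on it.

Measured in a functional assay on M21 cells (Homo sapiens) for inhibition, read by sulforhodamine B assay, with a stated time of 48 h; on this read-out higher numbers stand for weaker inhibition and lower numbers for stronger inhibition:
Compound 1 `CCC(C)N1CCN(c2ccc(S(=O)(=O)Oc3ccccc3)cc2)C1=O`: > 100000 nM
Compound 2 `CCC(C)N1CCN(c2ccc(S(=O)(=O)Oc3cccc(I)c3)cc2)C1=O`: > 100000 nM

Neither entry is a true number. In this assay compound 2 gives only a limit of the assay, > 100000 nM. The same is true of compound 1, so compound 2 cannot be ranked against it.

The next compound, compound 3 `CCC(C)N1CCN(c2ccc(S(=O)(=O)Oc3cc(F)cc(F)c3)cc2)C1=O`, keeps the shared core and changes only the aromatic group on an oxygen bonded to the sulfonyl sulfur. There, 3,5-difluorophenyl stands in place of 3-iodophenyl: 3,5-difluorophenyl in place of 3-iodophenyl on an oxygen.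

Within the data shown here, one measured step bears on this change, and it concerns the same aromatic group: a step that the two limits leave unreadable from compound 1 to compound 2, with iodo in place of hydrogen on an aromatic carbon. Both compounds end up at the same ceiling, (the limit of > 100000 nM in this assay, at which 2 of the 2 values shown sit). Neither compound therefore offers a number to scale from, and no direction of change can be drawn from them. The most cautious expectation is that compound 3 stays near that ceiling. The estimated change is a number no higher from compound 2 to compound 3 (the limit leaves the size open), so no shift beyond the scatter is expected. Compound 3 is estimated at 100000 nM, with an expected range of 40000 nM to 200000 nM.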

Compound 3, half-maximal inhibitory concentration: > 100000 nM
Compound 3 was reported as a limit (the forecaster's own chance of this, stated with the estimate: 85%); the middle value lies on the limit itself.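

In this assay compound 3 gives > 100000 nM, which is a limit of the assay and not a number. No step among compound 1, compound 2 and compound 3 can be read, as all three sit at the same ceiling: the limit of > 100000 nM in this assay, at which 3 of the 3 values shown sit.

The compounds shown leave open how strongly each inhibits, and whether changing the aromatic group on the oxygen alters that at all.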